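The source may hold more compounds than are shown below. What is called first, only, known or untested is meant among the compounds shown, and "the series" means these compounds.

Three compounds built on a shared core were tested in a functional assay on PC-3 cells (Homo sapiens) for inhibition; on this read-out higher numbers stand for weaker inhibition and lower numbers for stronger inhibition. Compound 1 `Cc1c(C(=O)N/N=C\c2ccc(O)cc2)oc2cccc(O)c12` gives 21700 nM. Compound 2 `Cc1c(C(=O)N/N=C\c2cc(O)ccc2O)oc2cccc(O)c12` gives 95500 nM, and the move between these two is a 4.4-fold higher number from compound 1 to compound 2 (0.64 log units; beyond the scatter). Compound 3 `Cc1c(C(=O)N/N=C\c2cc([N+](=O)[O-])ccc2O)oc2cccc(O)c12` gives 17100 nM, reached through a 5.6-fold lower number from compound 2 to compound 3 (0.75 log units; beyond the scatter). Among the three, compound 3 carries the lowest number; compound 1 lies within the scatter of it, so those two cannot be ordered, while compound 2 stands clearly apart from compound 3.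

Compound 4 `Cc1c(C(=O)N/N=C\c2cc(F)ccc2O)oc2cccc(O)c12` has not been measured. Against compound 3 the change is fluoro in place of nitro on an aromatic carbon. Among the compounds with values here, the only measured step that touches this position is the exchange of hydroxy for nitro, a 5.6-fold lower number from compound 2 to compound 3 (0.75 log units; beyond the scatter), a modest lowering of the number. Fluoro is neither of those groups, and no measured compound carries it, so that step is only a rough guide. Because the lowering seen in a 5.6-fold lower number from compound 2 to compound 3 (0.75 log units; beyond the scatter) arrived with the nitro, taking the nitro away again is expected to give back part of that step, a moderate rise of a 2.0-fold higher number from compound 3 to compound 4 (0.31 log units; beyond the scatter). Compound 4 is therefore estimated at 35000 nM, with a range from 12000 nM to 100000 nM.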

Compound 4, half-maximal inhibitory concentration: 3170 nM
Compound 4: the middle estimate sits 11-fold (1.04 log units) above what was measured; measured number outside the range, below it.
By their numbers in this assay, from the lowest: compound 4; then compounds 3 and 1 (each within the scatter of the next); then compound 2.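

In this assay, within the data shown here, the group at this place, para to a hydroxy group, proves to matter more than the earlier compounds could show: swapping nitro for fluoro, a much smaller group by heavy-atom count, brings the number down further (a 5.4-fold lower number from compound 3 to compound 4 (0.73 log units; beyond the scatter)) instead of giving back part of the earlier gain. Nitro is therefore not needed for a low number here, and set against hydroxy at the same place, fluoro gives the largest change seen so far (a 30-fold lower number from compound 2 to compound 4 (1.48 log units; beyond the scatter)). The fluoro compound also stands clear of the compound with the 4-hydroxyphenyl group (a 6.8-fold lower number from compound 1 to compound 4 (0.84 log units; beyond the scatter)), so compound 4 now has the lowest number of the four, beyond the scatter of each of the others, whereas compound 1 and compound 3 still cannot be ordered.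

As far as these compounds go, how chloro, a methoxy group, an amine or a carboxylic acid at this same place would compare remains open, and four compounds cannot show whether the order seen here would hold for other groups. Nothing measured here explains why fluoro gives the lowest number of the series.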